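Swapping the benzyl(methyl)amino arm for a cyclohexylmethyl amine

The compounds below may be only part of what the source reports. "The series", "measured", "known", "first", "only" and "open" are said of these compounds alone.

Compound 1 `COc1cccc(-c2c(C)n(Cc3ccccc3F)c3nc(C(C)(C)C)c(CN(C)Cc4ccccc4)n3c2=O)c1`: 72 nM
Compound 2 `COC(=O)C(C)(C)c1nc2n(Cc3ccccc3F)c(C)c(-c3cccc(OC)c3)c(=O)n2c1CN(C)Cc1ccccc1`: 59 nM

Both measured compounds share a core and were tested in an assay on isolated protein for binding affinity to Gonadotropin-releasing hormone receptor (Homo sapiens); on this read-out higher numbers stand for weaker inhibition and lower numbers for stronger inhibition. Compound 1 and compound 2 sit within the scatter of each other: the step of a 1.2-fold lower number from compound 1 to compound 2 (0.09 log units; within the scatter), a methoxycarbonyl in place of a methyl on a saturated chain carbon bound to an aromatic carbon and two saturated chain carbons, left the number essentially unchanged.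

Compound 3 `COc1cccc(-c2c(C)n(Cc3ccccc3F)c3nc(C(C)(C)C)c(CNCC4CCCCC4)n3c2=O)c1` differs from compound 1 at another place: (cyclohexylmethyl)amino in place of benzyl(methyl)amino on a saturated chain carbon bound to an aromatic carbon. Among the measured compounds shown here, no measured step touches this arm, so the one step known, from compound 1 to compound 2, bears on it only as a sign that a small change elsewhere on this core passed without effect. As far as these compounds go, the aromatic ring becomes a non-aromatic one and a hydrogen-bond donor appears, which is untested here. Compound 3 is therefore expected to stay near compound 1, the step of a 1.2-fold higher number from compound 1 to compound 3 (0.07 log units; within the scatter) estimated to lie within the scatter but with a wide range, giving an estimate of 85 nM, between 25 nM and 300 nM.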

Compound 3, inhibition constant: 430 nM
Compound 3: middle estimate off by 5.1-fold (0.70 log units), on the low side; measured number outside the range, above it.
By their numbers in this assay, from the lowest: compounds 2 and 1 (each within the scatter of the next); then compound 3.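

The arm on this saturated chain carbon bound to an aromatic carbon matters in a way the earlier pair could not show: in this assay, replacing benzyl(methyl)amino with (cyclohexylmethyl)amino gives a 6.0-fold higher number from compound 1 to compound 3 (0.78 log units; beyond the scatter), which means weaker inhibition. This single swap changes two things at once, as an aromatic ring gives way to a non-aromatic one and a hydrogen-bond donor enters, so the step belongs to the swap as a whole and not to either feature alone. No measurement shown here explains the change in the number.

Which of the two features carries the step stays open; a (cyclohexylmethyl)(methyl)amino arm or a benzylamino arm would separate them. Also open, as far as these compounds go, is whether the same swap has a similar effect with the methoxycarbonyl group of compound 2 in place.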